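A few compounds are considered here, and "the series" means these few. Any claim that something is new, unique, unknown or untested is made for them only; others in the source may bear on it.

Measured so far in a functional assay on NCI-H522 cells (Homo sapiens) for inhibition, read by sulforhodamine B assay, with a stated time of 48 h; on this read-out higher numbers stand for weaker inhibition of growth and lower numbers for stronger inhibition of growth:
- compound 1 `CCOC(=O)[C@H](CCC(=O)O)NC(=O)c1ccc(Sc2nc3cc(N)cc(N)c3nc2-c2ccccc2)cc1`, for which compound 1 gives 21400 nM
- compound 2 `Nc1cc(N)c2nc(-c3ccccc3)c(Sc3ccc(F)cc3)nc2c1`, for which compound 2 gives only a limit, < 100000 nM
- compound 3 `COc1ccc(CNc2nc3cc(N)cc(N)c3nc2-c2ccccc2)cc1`, for which compound 3 gives 10000 nM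

The value of compound 2 is a limit of this assay and not a number, so compound 2 cannot be placed against compound 1 or compound 3 on the numbers shown; it sits at the limit of < 100000 nM in this assay, at which 1 of the 3 values shown sits. Among the measured compounds shown here, no pair of measured compounds differs in a single place, so no measured step is available.

Compound 4 `COc1ccc(Sc2nc3cc(N)cc(N)c3nc2-c2ccccc2)cc1` is not yet measured. It differs from compound 2 in one place: methoxy in place of fluoro on an aromatic carbon. Cut one bond further out, this reads (4-fluorophenyl)sulfanyl to (4-methoxyphenyl)sulfanyl.

Since compound 2 is known only as a limit, no direction of the step can be read from its own value. Compound 3, which also carries a methoxyphenyl group on the shared core, gives 10000 nM, and compound 1, which carries a sulfanyl link on the same core, gives 21400 nM, so compound 4 is expected to land in the same broad region. The step from compound 2 to compound 4 is therefore expected to be a step that the limit leaves unreadable from compound 2 to compound 4, toward stronger inhibition of growth than the limit of compound 2 allows to be ruled out. For compound 4 the estimated value in this assay is 20000 nM, with a range from 5000 nM to 80000 nM.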

Compound 4, concentration for 50% growth inhibition: 3240 nM
For compound 4 the middle estimate is 6.2-fold (0.79 log units) above the measured one, outside the stated range (below it).
By their numbers in this assay, from the lowest: compound 4; then compound 3; then compound 1.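

No step can be read from compound 2 to compound 4, since the entry for compound 2 is a limit and not a number: the limit of < 100000 nM in this assay, at which 1 of the 4 values shown sits.

The compounds shown leave open the direction and size of the effect on growth inhibition of methoxy in place of fluoro on an aromatic carbon.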